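Compound 1 to compound 3: a 4-methylpiperazin-1-yl replacement

A few compounds are considered here, and "the series" means these few. Any claim that something is new, unique, unknown or untested is made for them only; others in the source may bear on it.

In a functional assay on K562 cells (Homo sapiens) for antiproliferative activity, read by MTT assay, with a stated time of 72 h (a lower number here means a stronger inhibitor, a higher number a weaker inhibitor), compound 1 (`O=C(/C=C/c1ccc(/C=C/C(=O)c2ccccc2)cc1)NO`) gives 2280 nM and compound 2 (`CN1CCN(c2ccccc2C(=O)/C=C/c2ccc(/C=C/C(=O)NO)cc2)CC1`) gives 1600 nM so the two values lie within the scatter of each other. Going by the values given here, compound 3 (`CN1CCN(c2ccc(C(=O)/C=C/c3ccc(/C=C/C(=O)NO)cc3)cc2)CC1`) keeps the core of compound 1 and carries 4-methylpiperazin-1-yl in place of hydrogen on an aromatic carbon, para to a large group (4-methylpiperazin-1-yl in place of hydrogen on an aromatic carbon) as its only change. Among the compounds with values here, one measured step bears on this, the same replacement at a different aromatic carbon, which gives a 1.4-fold lower number from compound 1 to compound 2 (0.15 log units; within the scatter) and so stays inside the scatter. Within the data shown here, that single step is the only evidence, and the data do not yet show whether the place of the group matters. The expected step is a 1.4-fold lower number from compound 1 to compound 3 (0.15 log units; within the scatter) and no shift beyond the scatter is expected. The estimated value for compound 3 is 1600 nM with an expected range of 700 nM to 3500 nM at this stage.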

Compound 3, half-maximal inhibitory concentration: 900 nM
The estimate for compound 3 lay 1.8-fold (0.25 log units) above the measured number; the measured number falls inside the stated range.
By their numbers in this assay, from the lowest: compounds 3, 2 and 1 (each within the scatter of the next, the first and the last beyond it).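

In this assay, 4-methylpiperazin-1-yl on an aromatic carbon para to a large group gives a 2.5-fold lower number from compound 1 to compound 3 (0.40 log units; beyond the scatter), so this replacement now has a modest step beyond the scatter. At a different aromatic carbon, the same replacement gave a 1.4-fold lower number from compound 1 to compound 2 (0.15 log units; within the scatter), which stayed inside the scatter. Compound 2 at 1600 nM and compound 3 at 900 nM still lie within the scatter of each other, so these values do not separate the two places, and no measured information accounts for the step.

Still open, going by these compounds, is whether the step at this carbon depends on the whole 4-methylpiperazin-1-yl group or would also appear with piperazin-1-yl, morpholin-4-yl or dimethylamino. The compounds shown also leave open how a carboxylic acid at the same carbon would compare.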